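The source may report more compounds than this note shows. Statements on the series, on what has been measured and on what is new or still open speak of the compounds shown alone.

Measured so far in a functional assay on CHO-K1 cells for antagonist activity at C-X-C chemokine receptor type 3 (Homo sapiens), read by FLIPR and calcium flux; a higher number here means a weaker inhibitor, a lower number a stronger inhibitor:
Compound 1, `C[C@@H]1CN(c2ccc(C(F)(F)F)cn2)[C@@H](C)CN1S(=O)(=O)C[C@]12CC[C@H](CC1=O)C2(C)C`, gives 6310 nM.
Compound 3, `CC1(C)[C@@H]2CC[C@@]1(CS(=O)(=O)N1CCN(c3nc(Cl)c(C(F)(F)F)cc3Cl)CC1)C(=O)C2`, gives 316 nM.
Compound 2, `CC1(C)[C@@H]2CC[C@@]1(CS(=O)(=O)N1CCN(c3ccc([N+](=O)[O-])cn3)CC1)C(=O)C2`, reaches only a limit of the assay, > 31600 nM.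

Compound 2 thus stands at the limit of > 31600 nM in this assay, at which 1 of the 3 values shown sits, with no number of its own, whereas compound 1 and compound 3 each have a measurable value, and compound 3 is the stronger of those two. Compound 4, `CC1(C)[C@@H]2CC[C@@]1(CS(=O)(=O)N1CCN(c3ccc(C(F)(F)F)nn3)CC1)C(=O)C2`, has not yet been measured. It differs from compound 2 in one place: 6-(trifluoromethyl)pyridazin-3-yl in place of 5-nitropyridin-2-yl on an amine nitrogen in a ring. Among the compounds with values here, no step between two measured compounds isolates this change, so any expectation rests on the three values alone. Because compound 2 sits at the limit of > 31600 nM in this assay, at which 1 of the 3 values shown sits, a measurable step can only go toward stronger inhibition. Compound 4 is expected near 10000 nM, within 2000 nM to 31600 nM. The expected step from compound 2 to compound 4 is an at least 3.1-fold lower number from compound 2 to compound 4 (0.49 log units; beyond the scatter), a gain, though a further limit is estimated as quite possible.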

Compound 4, half-maximal inhibitory concentration: 5010 nM
Compound 4: middle estimate off by 2.0-fold (0.30 log units), on the high side, within the range that was stated.
By their numbers in this assay, from the lowest: compound 3; then compounds 4 and 1 (each within the scatter of the next). At a limit, above all of these: compound 2.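

The result in this assay shows that this amine nitrogen in a ring can carry a different aromatic ring and still give a measurable inhibitor: 6-(trifluoromethyl)pyridazin-3-yl in place of 5-nitropyridin-2-yl gives an at least 6.3-fold lower number from compound 2 to compound 4 (0.79 log units; beyond the scatter) and so a real number. As far as these compounds go, the true size of that gain stays unknown, since compound 2 holds only a limit of the assay: the limit of > 31600 nM in this assay, at which 1 of the 4 values shown sits. The ring and the group it carries change together here, and the compounds shown do not separate the two. From the compounds shown here alone, how a nitrile or an amine in place of the trifluoromethyl would fare also stays open.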